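A few compounds are considered here, and "the series" means these few. Any claim that something is new, unique, unknown or untested is made for them only; others in the source may bear on it.

Series notes. Compound 2 `O=C(Nc1cc(Cl)cc(Cl)c1)c1cc(Cl)ccc1O` and compound 1 `O=C(Nc1cccc(C(F)(F)F)c1)c1cc(Cl)ccc1O` share one core and differ only in the substitution of the anilide ring. In an assay on cells for antagonist activity at P2X purinoceptor 7 (Homo sapiens), read by fluorescence and calcium flux, with a stated time of 30 min (on this read-out higher numbers stand for weaker inhibition and lower numbers for stronger inhibition), compound 2 gives 70.4 nM, the lowest number of the two values in hand. Among the compounds with values here, compound 1 gives 6320 nM in this assay, a gap from compound 2 that lies well beyond the scatter; no single step between them is counted, so the two numbers are only set side by side.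

Compound 3 `O=C(Nc1cccc(Cl)c1)c1cc(Cl)ccc1O` has not been measured in this assay. It differs from compound 2 by hydrogen in place of chloro on an aromatic carbon. Within the data shown here, no measured step of this kind exists, so the expectation rests on the two numbers above: the more heavily substituted anilide of compound 2 sits far lower than compound 1, and one chloro fewer is expected to move the number upward, as a 9.9-fold higher number from compound 2 to compound 3 (1.00 log units; beyond the scatter), clearly beyond the scatter. For compound 3 the expected value in this assay is 700 nM, within 200 nM to 3000 nM.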

Compound 3, half-maximal inhibitory concentration: 599 nM
Estimate against measurement, compound 3: 1.2-fold (0.07 log units) above; the range from low to high includes it.
By their numbers in this assay, from the lowest: compound 2; then compound 3; then compound 1.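

In this assay, hydrogen in place of chloro on an aromatic carbon, meta to a chloro group, carries a clear cost (an 8.5-fold higher number from compound 2 to compound 3 (0.93 log units; beyond the scatter)), so this position is not indifferent to what it holds. Chloro in place of trifluoromethyl on an aromatic carbon moves the number the other way (an 11-fold lower number from compound 1 to compound 3 (1.02 log units; beyond the scatter)), and the two values that earlier stood only side by side are now joined through two single changes. Nothing in hand gives a reason for either step.

Still open, on these data alone, is how other groups on this aromatic carbon, such as bromine, a methyl or a nitrile, or an amine or a carboxylic acid on the anilide ring, would read. Also open is what the hydroxyl group and the chloro on the shared core contribute: every compound shown keeps both.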